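Chlorophenylsulfonyl guanidine quinolones: ring substitution and nitrogen alkyl

The source may hold more compounds than are shown below. What is called first, only, known or untested is meant among the compounds shown, and "the series" means these compounds.

Compound 1 `CCn1cc(C(=O)O)c(=O)c2cc(F)c(N3CCN(C(=N)NS(=O)(=O)c4cccc(Cl)c4)CC3)cc21` gives 71 nM in a functional assay on A549 cells (Homo sapiens) for antiproliferative activity, read by MTT assay, with a stated time of 72 h; a higher number here means a weaker inhibitor, a lower number a stronger inhibitor. Compound 2 `CCn1cc(C(=O)O)c(=O)c2cc(F)c(N3CCN(C(=N)NS(=O)(=O)c4ccccc4Cl)CC3)cc21` gives 71 nM in this assay, and compound 3 `N=C(NS(=O)(=O)c1ccccc1Cl)N1CCN(c2cc3c(cc2F)c(=O)c(C(=O)O)cn3C2CC2)CC1` gives 71 nM. The step of no change at the digits printed from compound 2 to compound 1 (within the scatter) is 3-chlorophenyl in place of 2-chlorophenyl on a sulfonyl sulfur; the step of no change at the digits printed from compound 2 to compound 3 (within the scatter) is cyclopropyl in place of ethyl on an aromatic nitrogen, which is also how the core of compound 3 differs from that of compound 2. Compound 4 `N=C(NS(=O)(=O)c1cccc(Cl)c1)N1CCN(c2cc3c(cc2F)c(=O)c(C(=O)O)cn3C2CC2)CC1` is not yet measured; it differs from compound 3 by 3-chlorophenyl in place of 2-chlorophenyl on a sulfonyl sulfur, the same change as from compound 2 to compound 1, at a place described in the same words. Since that change left no change at the digits printed from compound 2 to compound 1 (within the scatter) on the ethyl core, the step of no change at the digits printed from compound 3 to compound 4 (within the scatter) is expected to be flat as well. Compound 4 is estimated at 71 nM in this assay, between 35 nM and 145 nM.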

Compound 4, half-maximal inhibitory concentration: 71 nM
Beside the measured number, compound 4's estimate shows no gap at the digits printed; the range from low to high includes it.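

In this assay, 3-chlorophenyl in place of 2-chlorophenyl on the cyclopropyl core gives no change at the digits printed from compound 3 to compound 4 (within the scatter), matching the ethyl core: the same change on two cores in this assay, no change at the digits printed (within the scatter) from compound 2 to compound 1 and no change at the digits printed (within the scatter) from compound 3 to compound 4, 1.0-fold (0.00 log units) apart, within the scatter of two such steps

Cyclopropyl in place of ethyl with the 3-chlorophenyl group present gives no change at the digits printed from compound 1 to compound 4 (within the scatter), again matching the earlier step: the same change on two cores in this assay, no change at the digits printed (within the scatter) from compound 2 to compound 3 and no change at the digits printed (within the scatter) from compound 1 to compound 4, 1.0-fold (0.00 log units) apart, within the scatter of two such steps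

Both changes therefore stay flat on the two cores shown, but flat steps do not show that a change with a real effect would carry from one core to another, nor that these two would stay flat on any further core.

Still open, going by these compounds, is whether a plain phenyl or a methyl on the sulfonyl sulfur, or a propyl chain on the aromatic nitrogen, would leave the values level. On these data alone, an amide in place of the carboxylic acid is equally open.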